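The source may report more compounds than this note shows. Statements on the series, on what has been measured and on what is new or still open speak of the compounds shown alone.

Working notes on the series

Compound 1, `O=C1C(N2CCCCC2)=CC(=O)c2c1nc1n2[C@H]2OC[C@@H](O)[C@H]2OC1`, has in a functional assay on MGC-803 cells (Homo sapiens) for inhibition, read by sulforhodamine B assay (a lower number here means a stronger inhibitor, a higher number a weaker inhibitor), only a limit, > 4000 nM (the limit of > 4000 nM in this assay, at which 1 of the 3 values shown sits). Compound 2, `COc1cccc(NC2=CC(=O)c3c(nc4n3[C@H]3OC[C@@H](O)[C@H]3OC4)C2=O)c1`, gives in this assay a value of 1790 nM. The change between them is (3-methoxyphenyl)amino in place of piperidin-1-yl on a double-bonded ring carbon, and the step it makes is an at least 2.2-fold lower number from compound 1 to compound 2 (0.34 log units; beyond the scatter), which reads as a gain against the limit of compound 1.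

Compound 3, `O=C1C=C(N2CCCCC2)C(=O)c2c1nc1n2[C@H]2OC[C@@H](O)[C@H]2OC1`, has in this assay only a limit, > 8000 nM (the limit of > 8000 nM in this assay, at which 1 of the 3 values shown sits). Compound 3 carries the same atoms as compound 1 joined differently; how the two cores differ is not broken down here.

Compound 4, `COc1cccc(NC2=CC(=O)c3nc4n(c3C2=O)[C@H]2OC[C@@H](O)[C@H]2OC4)c1`, is still to be measured in this assay. It stands to compound 3 as compound 2 stands to compound 1, through ((3-methoxyphenyl)amino in place of piperidin-1-yl on a double-bonded ring carbon); the place is the same word for word, so this is the same change. Since compound 3 starts from a limit, only the direction can be carried over: a step of about an at least 2.0-fold lower number from compound 3 to compound 4 (0.30 log units; that floor lies within the scatter) is expected for compound 4, resting on an at least 2.2-fold lower number from compound 1 to compound 2 (0.34 log units; beyond the scatter). Compound 4 is estimated at 4000 nM, with a range of 1200 nM to 15000 nM.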

Compound 4, half-maximal inhibitory concentration: 1780 nM
Beside the measured number, compound 4's estimate is 2.2-fold (0.35 log units) above it; the range from low to high includes it.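

In this assay, (3-methoxyphenyl)amino in place of piperidin-1-yl on a double-bonded ring carbon gives an at least 4.4-fold lower number from compound 3 to compound 4 (0.65 log units; beyond the scatter), so the direction seen on the core of compound 1 also appears on the core of compound 3. Set side by side, the two steps read: the same change on two cores in this assay, an at least 2.2-fold lower number (0.34 log units; beyond the scatter) from compound 1 to compound 2 and an at least 4.4-fold lower number (0.65 log units; beyond the scatter) from compound 3 to compound 4; the limit leaves it open whether they differ. Compound 3 has only a limit, > 8000 nM, so this pair fixes the direction and a floor for the step but not its true size, and two cores cannot show that the change carries over to any other core.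

Only these two groups are shown at this place, so it stays open whether the direction depends on the methoxy group or the aromatic ring, or whether an unsubstituted phenylamino group would follow it. A morpholin-4-yl group or a short open-chain amine on the same double-bonded ring carbon would also remain to be compared on both cores.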